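Swapping a methoxyphenyl for an indolyl: a solubility step

The source may report more compounds than this note shows. Statements on the series, on what has been measured and on what is new or still open speak of the compounds shown alone.

Compound 1 `CNC(=O)c1cc(C(=O)NC2CC2)cn(Cc2cccc(OC)c2)c1=O`: 582 ug/mL
Compound 2 `CNC(=O)c1cc(C(=O)NC2CCC2)cn(Cc2cccnc2)c1=O`: 189 ug/mL
Compound 3 `CNC(=O)c1cc(C(=O)NC2CC2)cn(Cc2cccc3cc[nH]c23)c1=O`: 11 ug/mL

In a physicochemical assay for solubility, read by HPLC, in simulated intestinal fluid, with a stated time of 16 h, tested at 125 ug/mL (on this read-out lower numbers stand for lower solubility and higher numbers for higher solubility), compound 1 gives 582 ug/mL and stands highest of the three measured compounds, with compound 2 nearest and compound 3 furthest from it. Compound 4 `CNC(=O)c1cc(C(=O)NC2CC2)cn(Cc2cccc3[nH]ccc23)c1=O` is not yet measured; it differs from compound 1 in one place: 1H-indol-4-yl in place of 3-methoxyphenyl on a saturated chain carbon bound to an aromatic nitrogen. Among the compounds with values here, the one measured step that bears on this change is a 53-fold lower number from compound 1 to compound 3 (1.72 log units; beyond the scatter), where an isomer of the same indolyl group entered at the same place. On that basis a large drop in this assay is expected for compound 4, on the order of a 29-fold lower number from compound 1 to compound 4 (1.46 log units; beyond the scatter). Compound 4 is therefore estimated at 20 ug/mL, with a range from 6 ug/mL to 70 ug/mL.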

Compound 4, solubility: 17 ug/mL
Compound 4: middle estimate off by 1.2-fold (0.07 log units), on the high side; the measured number falls inside the stated range.
By their numbers in this assay, from the lowest: compounds 3 and 4 (each within the scatter of the next); then compound 2; then compound 1.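

In this assay the large drop is not confined to the 1H-indol-7-yl group: 1H-indol-4-yl on the same saturated chain carbon gives a 34-fold lower number from compound 1 to compound 4 (1.53 log units; beyond the scatter). The exchange of one indolyl isomer for the other gives a 1.5-fold higher number from compound 3 to compound 4 (0.19 log units; within the scatter), which lies within the scatter, so these two isomers cannot be told apart here. Nothing measured explains the drop from 3-methoxyphenyl to either indolyl group. Still open, on these data alone, is whether an amine or a carboxylic acid on the indolyl group, or a longer chain in place of the saturated chain carbon, would change the number in this assay.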